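4-(tert-Butyl)-1,3-thiazol-5-yl in place of 3-(tert-butyl)-1H-pyrazol-5-yl

This account rests on a few compounds, and the source may have more. Where it says the series, first, only, none or still open, it means among the compounds named here.

Compound 2 `COC(=O)CCNC(=O)[C@@H]1O[P@@](=O)(OCOC(=O)c2cc(C(C)(C)C)n[nH]2)OCC1(C)C` stands in an ADME assay on blood (Homo sapiens) for pharmacokinetics (a lower number here means that the compound disappears faster, a higher number that the compound lasts longer), only at a limit of the assay, giving > 1 h. Compound 1 `COC(=O)CCNC(=O)[C@@H]1O[P@@](=O)(OCOC(=O)c2ccnn2C)OCC1(C)C` gives > 1 h in this assay, likewise a limit. Among the measured compounds shown here, the single measured step, a step that the two limits leave unreadable from compound 1 to compound 2, is therefore of unreadable size, as the limit of > 1 h in this assay, at which 2 of the 2 values shown sit, shows. Compound 3 `COC(=O)CCNC(=O)[C@@H]1O[P@@](=O)(OCOC(=O)c2scnc2C(C)(C)C)OCC1(C)C` differs from compound 2 by 4-(tert-butyl)-1,3-thiazol-5-yl in place of 3-(tert-butyl)-1H-pyrazol-5-yl on a carbonyl carbon. For the measured compounds named here, no measured step bears on this change, so no move beyond the scatter is expected, and the estimated step is a step that the limit leaves unreadable from compound 2 to compound 3. Compound 3 is accordingly expected to give about 2 h in this assay, between 1 h and 4 h.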

Compound 3, half-life: > 1 h
Compound 3 gave a limit, no number; the forecaster's own chance of this, stated with the estimate: 70%; the middle value lies beyond the limit too.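

Among the compounds shown here, no step among compound 1, compound 2 and compound 3 can be read in this assay, because each gives only a limit: the limit of > 1 h in this assay, at which 3 of the 3 values shown sit. As far as these compounds go, how far the half-life of each compound extends past that limit remains open, and so does whether the three differ at all.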